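The compounds below may be only part of what the source reports. "The series", "measured", "known", "first", "only" and "open" are said of these compounds alone.

Measured in an ADME assay on CNE-2 cells (Homo sapiens) for cytotoxicity, read by MTT assay, with a stated time of 48 h (on this read-out higher numbers stand for weaker inhibition and lower numbers for stronger inhibition), so far:
- compound 1 `COc1ccc(-c2cn(Cc3ccc(C(C)(C)C)cc3)nn2)cc1` gives 4000 nM
- compound 2 `CC(C)(C)c1ccc(Cn2cc(-c3ccc(O)cc3)nn2)cc1` gives 5600 nM
- compound 3 `CC(C)(C)c1ccc(Cn2cc(-c3ccc(O)cc3[N+](=O)[O-])nn2)cc1` gives 1600 nM

Compound 3 has the lowest number of the three, and its gap to each of the other two lies beyond the scatter. The next compound is compound 4 `CC(C)(C)c1ccc(Cn2cc(-c3ccc(O)cc3N)nn2)cc1`, which is still unmeasured. The change is amino in place of nitro on an aromatic carbon in short, amino in place of nitro on an aromatic carbon, ortho to a large group and meta to a hydroxy group.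

Within the data shown here, only one measured step touches this carbon. That is a 3.5-fold lower number from compound 2 to compound 3 (0.54 log units; beyond the scatter) for nitro in place of hydrogen, a modest move toward stronger inhibition. The other step, a 1.4-fold higher number from compound 1 to compound 2 (0.15 log units; within the scatter) at the oxygen, lies within the scatter and says little here. Among the measured compounds shown here, no amino compound has been measured, so the direction rests on a single comparison. Removing the nitro may give back part of the step seen from compound 2, and a small move toward higher numbers is expected, short of the full return.

The step expected in this assay is a 1.9-fold higher number from compound 3 to compound 4 (0.27 log units; within the scatter) as an estimate. For compound 4 the estimated value is 3000 nM with an expected range from 1200 nM to 8000 nM as a working guess.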

Compound 4, half-maximal inhibitory concentration: 1600 nM
Compound 4: middle estimate off by 1.9-fold (0.27 log units), on the high side; the measured number falls inside the stated range.
By their numbers in this assay, from the lowest: compounds 3 and 4 (each within the scatter of the next); then compounds 1 and 2 (each within the scatter of the next).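

In this assay, amino in place of nitro on this aromatic carbon leaves the number unmoved (no change at the digits printed from compound 3 to compound 4 (within the scatter)), so the lower number seen with nitro is not confined to nitro, even though the two groups differ in heavy atoms and hydrogen-bond donors. Against hydrogen at the same carbon, amino gives the same size of step as nitro (a 3.5-fold lower number from compound 2 to compound 4 (0.54 log units; beyond the scatter)), and the comparison for 2-amino-4-hydroxyphenyl in place of 4-methoxyphenyl points the same way (a 2.5-fold lower number from compound 1 to compound 4 (0.40 log units; beyond the scatter)), so in these four compounds both substituents on this carbon stand apart from hydrogen, with no compound going against this. Nothing available here accounts for this result.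

Going by these compounds, whether the lower number needs a nitrogen-linked group remains open, since a chlorine, a methyl or a carboxylic acid on this carbon would separate a nitrogen-specific result from a result of any substituent there. An acetamide in place of the amino, and a methoxy in place of the hydroxy with the amino kept, would also test how far this tolerance extends.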